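The compounds below may be only part of what the source reports. "The series", "measured", "known", "first", "only" and "open" are said of these compounds alone.

Working notes on a set of amides built on one shared core and tested in a functional assay on the whole organism for antagonist activity, with Mus musculus as the target; a higher number here means that more compound is needed for the effect, a lower number that less compound is needed. Compound 1 `CCCCCCN1CCC(C(=O)Nc2cc(Cl)c(N)cc2OC)CC1` reaches only the limit > 10 mg/kg in this assay, which is a limit and not a number. Compound 2 `COc1cc(N)c(Cl)cc1NC(=O)C1CCN(CC2CC2)CC1` likewise stops at the limit > 10 mg/kg in this assay. Among the measured compounds shown here, compound 3 `CCOc1ccc(CN2CCC(C(=O)Nc3cc(Cl)c(N)cc3OC)CC2)cc1` gives 6.3 mg/kg in this assay, the only number in the set so far. The two other values, those of compound 1 and compound 2, sit at the limit of > 10 mg/kg in this assay, at which 2 of the 3 values shown sit. The step of an at least 1.5-fold lower number from compound 1 to compound 3 (0.20 log units; that floor lies within the scatter) and the step of an at least 1.5-fold lower number from compound 2 to compound 3 (0.20 log units; that floor lies within the scatter) both run downward from a limit, so only a floor is readable for each, and that floor is within the scatter. The step that the two limits leave unreadable from compound 1 to compound 2 cannot be read at all. For the measured compounds named here, compound 4 `COc1cc(N)c(Cl)cc1NC(=O)C1CCN(Cc2ccccc2F)CC1` is the next member. 2-fluorophenyl in place of 4-ethoxyphenyl on a saturated chain carbon bound to an amine nitrogen in a ring No measured step swaps one six-membered aromatic ring of carbon only for another; the three measured steps exchange the whole group on that carbon, and the two readable ones give only floors within the scatter. No direction can be drawn from them, so for compound 4 the expected step is a 1.3-fold higher number from compound 3 to compound 4 (0.10 log units; within the scatter), close to none beyond the scatter, with the limit near. Compound 4 is thus expected in this assay to give 8 mg/kg, ranging from 3 mg/kg to 20 mg/kg.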

Compound 4, dose for half-maximal effect: > 4 mg/kg
Compound 4 gave a limit, no number; the forecaster's own chance of this, stated with the estimate: 40%; the middle value lies beyond the limit too.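

In this assay compound 4 gives > 4 mg/kg, which is a limit and not a number. None of its steps from compound 1, compound 2 or compound 3 can be read. The compounds shown leave open whether 2-fluorophenyl in place of 4-ethoxyphenyl on a saturated chain carbon bound to an amine nitrogen in a ring changes the dose.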